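A few compounds are considered here, and "the series" means these few. Any claim that something is new, unique, unknown or untested is made for them only; others in the source may bear on it.

Compound 1 `CC(=O)Nn1c(NCc2ccc(-c3cc(Cl)cc(F)c3-c3noc(C)n3)cc2F)nc(C)c1C` is the reference point of this series. Going by the values given here, in a functional assay on IMR-90 cells for antagonist activity at B1 bradykinin receptor (Homo sapiens), read by calcium flux (on this read-out higher numbers stand for weaker inhibition and lower numbers for stronger inhibition), compound 1 gives 180 nM, the only number in hand, since compound 2 `CC(=O)Nc1c[nH]nc1NCc1ccc(-c2cc(Cl)cc(F)c2-c2noc(C)n2)cc1F` carries in this assay the entry "not determined" (no result reported). Among the compounds with values here, no step between measured compounds is therefore available. Compound 3 `COc1cc(C(=O)Nn2c(NCc3ccc(-c4cc(Cl)cc(F)c4-c4noc(C)n4)cc3F)nc(C)c2C)on1` differs from compound 1 in one place: 3-methoxy-1,2-oxazol-5-yl in place of methyl on a carbonyl carbon. Within the data shown here, with no comparable pair to lean on, the size of the step in this assay cannot be read from the data; the working expectation is a change of no more than the usual scatter, in either direction, with a wide allowance around it. On this basis compound 3 is estimated at 150 nM in this assay, with a range from 40 nM to 500 nM. That estimate corresponds to an expected step of a 1.2-fold lower number from compound 1 to compound 3 (0.08 log units; within the scatter).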

Compound 3, half-maximal inhibitory concentration: 85 nM
Beside the measured number, compound 3's estimate is 1.8-fold (0.25 log units) above it, and the stated range covers the measured number.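

The acyl group on the amide-type nitrogen need not stay a small acetyl: in this assay, 3-methoxy-1,2-oxazol-5-yl in place of methyl on the carbonyl carbon gives a 2.1-fold lower number from compound 1 to compound 3 (0.33 log units; beyond the scatter) and so a modest gain rather than a loss. Going by these compounds alone, this is the first readable step, and it shows that a five-membered aromatic ring carrying a methoxy group is accepted at this place, though the finding rests on this single pair. Nothing on hand bears on the reason for the step.

Open, from the compounds shown here alone, is whether the ring or its methoxy group carries the step, which unsubstituted 1,2-oxazol-5-yl, phenyl or a longer alkyl chain on the same carbonyl carbon would help to separate. Steps involving compound 2 cannot be read, so whether the change would hold on that other core also remains open.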